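Alkynyl and aryl groups on the shared core

A few compounds are considered here, and "the series" means these few. Any claim that something is new, unique, unknown or untested is made for them only; others in the source may bear on it.

Values in a functional assay on CAPAN-1 cells (Homo sapiens) for antiproliferative activity, with a stated time of 72 h; on this read-out higher numbers stand for weaker inhibition and lower numbers for stronger inhibition:
- compound 1 `Nc1ncnn2c([C@@H]3O[C@H](CO)[C@@H](O)[C@H]3O)cc(C#CC3CC3)c12`: 20 nM
- compound 2 `Nc1ncnn2c([C@@H]3O[C@H](CO)[C@@H](O)[C@H]3O)cc(C#Cc3ccc(F)cc3)c12`: 55400 nM
- compound 3 `Nc1ncnn2c([C@@H]3O[C@H](CO)[C@@H](O)[C@H]3O)cc(C#Cc3cccs3)c12`: 32000 nM
- compound 4 `Nc1ncnn2c([C@@H]3O[C@H](CO)[C@@H](O)[C@H]3O)cc(-c3ccc(F)cc3)c12`: not yet measured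

Compound 3 lies level with compound 2, within the scatter: a 1.7-fold lower number from compound 2 to compound 3 (0.24 log units; within the scatter). Both stand far from compound 1: a 1600-fold higher number from compound 1 to compound 3 (3.20 log units; beyond the scatter), and a 2800-fold higher number from compound 1 to compound 2 (3.44 log units; beyond the scatter).

The next change is 4-fluorophenyl in place of 2-(thiophen-2-yl)ethynyl on an aromatic carbon. Among the measured compounds shown here, no measured step removes the triple bond, so none matches this change directly. The large steps concern only the loss of cyclopropyl, which compound 3 already lacks. Compound 2, carrying 4-fluorophenyl on a triple-bonded carbon, gives 55400 nM.

No step beyond the scatter is therefore expected in this assay, though with wide uncertainty in either direction. The expected step is a 1.1-fold lower number from compound 3 to compound 4 (0.03 log units; within the scatter). For compound 4 the estimated value is 30000 nM, with an expected range of 3000 nM to 100000 nM.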

Compound 4, half-maximal inhibitory concentration: 65600 nM
Compound 4: middle estimate off by 2.2-fold (0.34 log units), on the low side; the measured number falls inside the stated range.
By their numbers in this assay, from the lowest: compound 1; then compounds 3, 2 and 4 (each within the scatter of the next, the first and the last beyond it).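

In this assay, a 4-fluorophenyl bound directly to the aromatic carbon gives no return toward the low number of the cyclopropyl alkyne, with a 3300-fold higher number from compound 1 to compound 4 (3.52 log units; beyond the scatter) as the large step. Loss of the triple bond leaves the 4-fluorophenyl pair level, with a 1.2-fold higher number from compound 2 to compound 4 (0.07 log units; within the scatter) as the step, and only a modest difference appears in a 2.1-fold higher number from compound 3 to compound 4 (0.31 log units; beyond the scatter) against the thiophene alkyne. No evidence on the cause of these differences is available.

Still open, from the compounds shown here alone, is whether cyclopropyl bound directly to the aromatic carbon keeps the low number of compound 1. Also open, going by these compounds, is whether cyclobutyl or a linear propyl chain on the triple bond does so.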